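The source may hold more compounds than are shown below. What is called first, only, known or untested is meant among the compounds shown, and "the series" means these compounds.

Compound 3 is `COC(=O)/C=C/c1cccc(N(Cc2ccccc2Br)C(=O)C2CCCCC2)c1`. In an assay on isolated protein with Bile acid receptor (Homo sapiens) as the target (on this read-out lower numbers stand for an effect already at smaller amounts and higher numbers for an effect only at larger amounts of compound), compound 3 reaches only > 1000 nM, which is a limit of the assay rather than a number; it therefore stands at the limit of > 1000 nM in this assay, at which 1 of the 3 values shown sits. Compound 4 is `COC(=O)/C=C/c1cccc(N(Cc2ccc(/C=C/C(=O)O)cc2)C(=O)C2CCCCC2)c1`, and the change from compound 3 is 4-(2-carboxyethenyl)phenyl in place of 2-bromophenyl on a saturated chain carbon bound to an amide-type nitrogen. Among the measured compounds shown here, no measured step covers this exact change. Compound 1, `COC(=O)/C=C/c1cccc(N(Cc2ccc(-c3ccc(F)c(F)c3)cc2)C(=O)C2CCCCC2)c1`, gives 72 nM, and compound 2, `COC(=O)/C=C/c1cccc(N(Cc2ccc(-c3ccc(C(C)(C)C)cc3)cc2)C(=O)C2CCCCC2)c1`, gives 132 nM, while a 1.8-fold higher number from compound 1 to compound 2 (0.26 log units; within the scatter) shows that swapping one group on that outer ring changes little. Since compound 4 likewise carries a group at the 4-position of its phenyl, a move towards those values is expected, yielding an estimate of an at least 3.3-fold lower number from compound 3 to compound 4 (0.52 log units; beyond the scatter). Compound 4 is thus estimated at 300 nM, between 60 nM and 1500 nM.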

Compound 4, half-maximal effective concentration: > 1000 nM
Compound 4 ended at the assay's limit; the forecaster's own chance of this, stated with the estimate: 25%; middle value at least 3.3-fold (0.52 log units) away from the limit.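

In this assay, 2-carboxyethenyl on this aromatic carbon gives an at least 7.5-fold higher number from compound 2 to compound 4 (0.87 log units; beyond the scatter), and likewise an at least 13-fold higher number from compound 1 to compound 4 (1.14 log units; beyond the scatter). The earlier swap between two aryl groups here gave only a 1.8-fold higher number from compound 1 to compound 2 (0.26 log units; within the scatter), so the choice of group at this carbon can matter after all. Compound 3 and compound 4 both stand at a limit, and the step between them cannot be read: the limit of > 1000 nM in this assay, at which 2 of the 4 values shown sit.

Still open, going by these compounds, is whether the carboxylic acid or the ethenyl chain accounts for this step. A plain phenyl or an amine at this carbon could help separate the two.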